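Trifluoromethyl in Place of Isopropyl on the Phenyl Substituent

The source may report more compounds than this note shows. Statements on the series, on what has been measured and on what is new or still open speak of the compounds shown alone.

For the measured compounds named here, compound 2 `CC(C)c1ccc(-n2nc(-c3ccccc3)nc2CNc2ccc(C(=O)NO)cc2)cc1` stands lowest of the two numbers known in an assay on Sf9 cells for inhibition of protein deacetylase HDAC6 (Homo sapiens), read by fluorescence, with a stated time of 40 min, tested at 100 nM (on this read-out higher numbers stand for more inhibition at the one concentration tested (going by the name of the read-out) and lower numbers for less inhibition), where compound 2 gives 52.6%; compound 1 `O=C(NO)c1ccc(NCc2nc(-c3ccccc3)nn2-c2ccccc2)cc1` gives 72.6%. Compound 3 `O=C(NO)c1ccc(NCc2nc(-c3ccccc3)nn2-c2ccc(C(F)(F)F)cc2)cc1` carries trifluoromethyl in place of isopropyl on an aromatic carbon. Going by the values given here, the only measured step touching this place is a number 20 percentage points lower from compound 1 to compound 2 (beyond the scatter), which shows that a group on this aromatic carbon can lower the read-out, but no measured step compares two such groups with each other. For compound 3 a step of a number 2.4 percentage points higher from compound 2 to compound 3 (within the scatter) is therefore expected, within the scatter. Compound 3 is estimated at 55%, with a range from 35% to 75%.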

Compound 3, a percentage reported as inhibition, at one concentration (the size of the read-out at that concentration, not a potency): 38.9%
Beside the measured number, compound 3's estimate is 16.1 percentage points above it; the range from low to high includes it.
By their numbers in this assay, from the lowest: compound 3; then compound 2; then compound 1.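

In this assay, the identity of the group on this aromatic carbon matters, not only its presence: trifluoromethyl in place of isopropyl gives a number 13.7 percentage points lower from compound 2 to compound 3 (beyond the scatter). Measured against hydrogen, trifluoromethyl gives a number 33.7 percentage points lower from compound 1 to compound 3 (beyond the scatter), a larger drop than isopropyl produced at this place. Nothing available explains why the two groups differ. As far as these compounds go, whether an amine, a methoxy group or a carboxylic acid on this carbon would also lower the read-out remains open, as does the effect of moving trifluoromethyl elsewhere on the ring.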